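The compounds below may be only part of what the source reports. "The series", "measured", "known", "first", "only" and "open" are said of these compounds alone.

Series notes. Compound 1 `CCCS(=O)(=O)Nc1cccc2c1CCCC2c1c[nH]cn1` and compound 2 `CC(=O)Nc1cccc2c1CCCC2c1c[nH]cn1` share one core and differ only in the group on the ring nitrogen, acetyl in place of propylsulfonyl. In an assay on isolated protein for binding affinity to Alpha-1D adrenergic receptor (Rattus norvegicus), read by radioligand binding (on this read-out higher numbers stand for weaker inhibition and lower numbers for stronger inhibition), compound 1 gives < 10000 nM, a limit of the assay rather than a number. In this assay compound 2 gives < 10000 nM, again a limit and not a number. The step that the two limits leave unreadable from compound 1 to compound 2 is accordingly unreadable since (the limit of < 10000 nM in this assay, at which 2 of the 2 values shown sit). Compound 2 thus stands at the limit, with no ranking possible against compound 1.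

Compound 3 `O=C(Nc1cccc2c1CCCC2c1c[nH]cn1)C(F)(F)F` carries trifluoromethyl in place of methyl on a carbonyl carbon. Among the compounds with values here, no measured step bears on this change: the only step in hand concerns the nitrogen substituent and is itself unreadable. Nothing supports a direction in this assay, so no step beyond the scatter is assumed. The expected step is a step that the limit leaves unreadable from compound 2 to compound 3. The estimate for compound 3 in this assay is 800 nM, within 80 nM to 8000 nM, with a sizeable chance of another limit.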

Compound 3, inhibition constant: 3310 nM
For compound 3 the middle estimate is 4.1-fold (0.62 log units) below the measured one; measured number inside the range.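

No step from compound 1 or compound 2 to compound 3 can be read, since compound 1 and compound 2 each sit at a limit and not at a number: the limit of < 10000 nM in this assay, at which 2 of the 3 values shown sit.

The compounds shown leave open how compound 3 ranks against compound 1 and compound 2, and how far trifluoromethyl in place of methyl on a carbonyl carbon moves the read-out.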